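Three Carbamates at the Assay Limit and a Dichlorophenyl Analogue

This account rests on a few compounds, and the source may have more. Where it says the series, first, only, none or still open, it means among the compounds named here.

Compounds measured in an assay for inhibition of zeta-carotene desaturase, chloroplastic/chromoplastic (Capsicum annuum), using a Dixon plot, with a stated time of 8 h; on this read-out lower numbers stand for stronger inhibition and higher numbers for weaker inhibition:
compound 1 `CCC(COc1cccc(Br)c1)OC(=O)NCc1ccccc1`, a limit of the assay: > 100000 nM
compound 2 `CCC(COc1cccc(C(C)C)c1)OC(=O)NCc1ccccc1`, a limit of the assay: > 100000 nM
compound 3 `CCC(COc1cccc(C(=O)O)c1)OC(=O)NCc1ccccc1`, a limit of the assay: > 100000 nM

Compound 1 stands at the limit, and so do compound 2 and compound 3 (the limit of > 100000 nM in this assay, at which 3 of the 3 values shown sit). Because of the limit of > 100000 nM in this assay, at which 3 of the 3 values shown sit, none of the three measured steps can be read: a step that the two limits leave unreadable from compound 1 to compound 2, a step that the two limits leave unreadable from compound 1 to compound 3 and a step that the two limits leave unreadable from compound 2 to compound 3. The substituent on the aromatic carbon has thus been varied across bromo, isopropyl and carboxy without any of the three compounds giving a number in this assay.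

Compound 4 `CCC(COc1ccc(Cl)c(Cl)c1)OC(=O)NCc1ccccc1` is the unmeasured member of the set. Against compound 1 the change is 3,4-dichlorophenyl in place of 3-bromophenyl on an oxygen on a saturated carbon. Going by the values given here, no measured step bears directly on this change; the three steps between compound 1, compound 2 and compound 3 are all unreadable, so they offer no size and no direction to transfer. What the set does show is that three different groups on the aromatic ring of the shared core all left the value at the limit.

On that basis the expected step is a step that the limit leaves unreadable from compound 1 to compound 4, meaning no readable change is expected. Compound 4 is therefore estimated at 150000 nM, with a range from 30000 nM to 1000000 nM, most likely reported again as a limit.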

Compound 4, half-maximal inhibitory concentration: > 100000 nM
Compound 4: a limit, no number (the forecaster's own chance of this, stated with the estimate: 80%); the middle value lies beyond the limit too.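

Compound 4 also gave only a limit, so no readable step connects compound 1 and compound 4, and neither can be ranked against the other: the limit of > 100000 nM in this assay, at which 4 of the 4 values shown sit.

The compounds shown leave open how far each of the four lies past that limit and whether any change to the shared core would give a number in this assay.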